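A few compounds are considered here, and "the series" means these few. Any claim that something is new, unique, unknown or untested is made for them only; others in the source may bear on it.

Series notes, aromatic group on the shared core. Compound 1 `O=C(NO)c1ccc(NCc2nc(-c3ccc(F)cc3)nn2-c2ccccc2)cc1` in an assay on Sf9 cells for inhibition of protein deacetylase HDAC6 (Homo sapiens), read by fluorescence, with a stated time of 40 min, tested at 100 nM (a lower number here means less inhibition, a higher number more inhibition at the concentration tested (going by the name of the read-out)), gives 70.9%. Among the compounds with values here, compound 2 `O=C(NO)c1ccc(NCc2nc(-c3ccc(Cl)c(Cl)c3)nn2-c2ccccc2)cc1` in this assay gives 34.5%; the one measured step, a number 36.4 percentage points lower from compound 1 to compound 2 (beyond the scatter), is the only change at this position so far. Compound 2 stands lowest of the two measured numbers, with compound 1 the nearest at a value beyond the scatter above it.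

Compound 3 `Cc1ccc(-c2nc(CNc3ccc(C(=O)NO)cc3)n(-c3ccccc3)n2)s1` is the next member: 5-methylthiophen-2-yl in place of 3,4-dichlorophenyl on an aromatic carbon. The step from compound 1 to compound 2 bears on it, as it touches the same place on the shared core, and it was large. Within the data shown here, the group entering here is not the one that left in that step, so the only guide is that this position can carry a group with a far higher number than compound 2 shows. A rise beyond the scatter, a number 20.5 percentage points higher from compound 2 to compound 3 (beyond the scatter), is expected. For compound 3 in this assay the estimate is 55%, within 30% to 80%.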

Compound 3, a percentage reported as inhibition, at one concentration (the size of the read-out at that concentration, not a potency): 79.7%
For compound 3 the middle estimate is 24.7 percentage points below the measured one; low and high end bracket the measured number.
By their numbers in this assay, from the lowest: compound 2; then compounds 1 and 3 (each within the scatter of the next).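

In this assay the exchange of 3,4-dichlorophenyl for 5-methylthiophen-2-yl gives a number 45.2 percentage points higher from compound 2 to compound 3 (beyond the scatter) and so shows that the low number of compound 2 does not hold for every aromatic group at this position. Set against 4-fluorophenyl, the same group gives a number 8.8 percentage points higher from compound 1 to compound 3 (within the scatter) and no order can be drawn, so a six-membered aromatic ring of carbon only and a five-membered aromatic ring with 1 hetero atom both reach the upper range of the series here. Nothing available bears on why the numbers fall as they do.

From the compounds shown here alone, whether the methyl group or the thiophene ring itself carries the number of compound 3 stays open, as the two are changed together in these compounds. Also open, going by these compounds, is how this position responds to a group such as an amine or a carboxylic acid on the aromatic ring.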